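A few compounds are considered here, and "the series" means these few. Any claim that something is new, unique, unknown or untested is made for them only; others in the source may bear on it.

Measured compounds:
- compound 1, `Nc1cc(N)c2nc(-c3ccccc3)c(Oc3ccc(F)cc3)nc2c1`: 20000 nM
- compound 2, `COc1ccc(CNc2nc3cc(N)cc(N)c3nc2-c2ccccc2)cc1`: 15500 nM

Both were tested in a functional assay on COLO 205 cells (Homo sapiens) for inhibition, read by sulforhodamine B assay, with a stated time of 48 h; a higher number here means a weaker inhibitor of growth, a lower number a stronger inhibitor of growth. Compound 1 gives 20000 nM, the highest of the two numbers, while compound 2 gives 15500 nM, a gap that lies within the scatter, so the two compounds cannot be told apart on these figures. Compound 3, `COc1ccc(Sc2nc3cc(N)cc(N)c3nc2-c2ccccc2)cc1`, has not yet been tested. It differs from compound 1 in one place: (4-methoxyphenyl)sulfanyl in place of 4-fluorophenoxy on an aromatic carbon. Going by the values given here, with no measured step to lean on, the expected step from compound 1 to compound 3 in this assay is small, a 1.7-fold lower number from compound 1 to compound 3 (0.22 log units; within the scatter), toward a slightly stronger inhibitor. Compound 3 is estimated at 12000 nM, within 4000 nM to 40000 nM.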

Compound 3, concentration for 50% growth inhibition: 19500 nM
The estimate for compound 3 lay 1.6-fold (0.21 log units) below the measured number, and the stated range covers the measured number.
By their numbers in this assay, from the lowest: compounds 2, 3 and 1 (each within the scatter of the next).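

In this assay, putting (4-methoxyphenyl)sulfanyl in place of 4-fluorophenoxy on this aromatic carbon gives a 1.0-fold lower number from compound 1 to compound 3 (0.01 log units; within the scatter). Going by these compounds alone, this is the first measured one-place change at this position, and the two groups cannot be told apart on growth inhibition. No available evidence accounts for this result.

Going by these compounds, the swap alters both the link to the ring and the ring's substituent, so the effect of each alone remains unknown. On these data alone, it also remains open whether a carboxylic acid or a methyl group here would give a number beyond the scatter.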